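The compounds below may be only part of what the source reports. "The series", "measured", "known", "first", "only" and "open" are said of these compounds alone.

In a functional assay on DU-145 cells (Homo sapiens) for inhibition, read by MTT assay, with stated times of 18 h and 4 h (on this read-out lower numbers stand for stronger inhibition and higher numbers for weaker inhibition), compound 1, `CCCCCCCCCCCCCCCCOP(=O)(O)OCCSC(=S)N1CCCCCC1`, gives 17600 nM, and compound 2, `CCCCCCCCOP(=O)(O)OCCSC(=S)N1CCCC1`, gives 47100 nM. Compound 3, `CCCOP(=O)(O)OCCSC(=S)N1CCCCC1`, reports only a limit, > 100000 nM. It therefore has no number of its own and rests on (the limit of > 100000 nM in this assay, at which 1 of the 3 values shown sits).

Compound 4, `CCCCCCCCOP(=O)(O)OCCSC(=S)N1CCCCC1`, departs from compound 3 by a single change, pentyl in place of hydrogen on a saturated chain carbon, three bonds along the chain from an oxygen on an unsaturated carbon. Read one bond further out, propyl becomes octyl.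

For the measured compounds named here, no measured pair isolates this change, so the expectation is indirect. Compound 2, which carries the same octyl chain, gives 47100 nM, a number inside the range of this assay. On that basis a move to a lower number, meaning stronger inhibition and lying beyond the usual scatter, is expected. As far as these compounds go, its exact size remains open, as the starting point is only a limit. The estimated move is an at least 2.5-fold lower number from compound 3 to compound 4 (0.39 log units; beyond the scatter). Compound 4 is estimated at 40000 nM, with an expected range from 16000 nM to 95000 nM.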

Compound 4, half-maximal inhibitory concentration: > 100000 nM
Compound 4: a limit, no number (the forecaster's own chance of this, stated with the estimate: 15%); at least 2.5-fold (0.39 log units) between middle value and limit.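

In this assay compound 4 gives > 100000 nM, which is a limit and not a number. For the compounds shown here, with the octyl chain held fixed, piperidin-1-yl in place of pyrrolidin-1-yl on a thiocarbonyl carbon gives an at least 2.1-fold higher number from compound 2 to compound 4 (0.32 log units; beyond the scatter), so this is the first readable sign that the group on the thiocarbonyl carbon matters, and that the octyl chain alone does not secure a value inside the range of the assay. Pentyl in place of hydrogen on the saturated chain carbon, by contrast, has no readable effect here, and the step that would show it cannot be read, as both of its ends are limits: the limit of > 100000 nM in this assay, at which 2 of the 4 values shown sit.

The compounds shown leave open whether a longer chain, such as dodecyl in place of octyl, would bring the compounds carrying piperidin-1-yl into the measurable range, as compound 1 differs from compound 4 in more than one place and offers no direct comparison. They also leave open how an open-chain amine such as dimethylamino on the thiocarbonyl carbon would compare with piperidin-1-yl and pyrrolidin-1-yl.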